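The source may report more compounds than this note shows. Statements on the series, on what has been measured and on what is new or still open speak of the compounds shown alone.

Measured compounds: compound 1 `Cc1nc2cc(Br)ccc2nc1N1CCCCC1` with 0.0403 ug/mL; compound 2 `Cc1nc2cc(Br)ccc2nc1NN` with 0.0206 ug/mL; compound 3 `Cc1nc2cc(Br)ccc2nc1Oc1ccc(N)cc1` with 0.00052 ug/mL.

All three were tested in a functional assay on NCI-H460 cells (Homo sapiens) for inhibition, read by sulforhodamine B assay, with a stated time of 72 h; a lower number here means a stronger inhibitor, a higher number a weaker inhibitor. Compound 3 gives the lowest number of the three, and its gap to compound 2 and to compound 1 lies beyond the scatter, so it is the strongest inhibitor in this set. Among the compounds with values here, the only step between two measured compounds that differ in one place is a 2.0-fold lower number from compound 1 to compound 2 (0.29 log units; within the scatter), a change on the shared core that does not touch the part of compound 3 that is altered next.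

Compound 4 `Cc1nc2cc(Br)ccc2nc1Oc1ccc(/N=C\c2ccc(Cl)cc2)cc1` differs from compound 3 by a group of 9 heavy atoms (7 carbon, 1 nitrogen, 1 chlorine; one six-membered aromatic ring of carbon only) in place of one nitrogen atom, on an aromatic carbon. Within the data shown here, no measured step concerns this ring, so the change has no direct precedent in these data. Among the measured compounds shown here, the one measured step was small, which gives no reason to expect a large shift, but the change here is considerably larger. The account therefore expects a moderate rise in the number, a 3.8-fold higher number from compound 3 to compound 4 (0.59 log units; beyond the scatter), and compound 4 is estimated at 0.002 ug/mL, between 0.0002 ug/mL and 0.02 ug/mL.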

Compound 4, half-maximal inhibitory concentration: 0.00008 ug/mL
The estimate for compound 4 lay 25-fold (1.40 log units) above the measured number; measured number below the stated range.
By their numbers in this assay, from the lowest: compound 4; then compound 3; then compounds 2 and 1 (each within the scatter of the next).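

At this position, para to a large group on the six-membered aromatic ring of carbon only, the amino group can give way to a far larger group without any loss, and the change gives a 6.5-fold lower number from compound 3 to compound 4 (0.81 log units; beyond the scatter). The entering group carries no hydrogen-bond donor, so a donor at this place is not required for a number as low as that of compound 4. Nothing available here explains why the number falls with this change.

The compounds shown leave open which part of the entering group goes with the step: the chlorine, the aromatic ring or the double bond outside it. Going by these compounds, how this place would respond to a carboxylic acid, a morpholine or a plain methoxy group also remains open.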